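From methyl to cyclohexyl ester: a cytotoxicity outlook

A few compounds are considered here, and "the series" means these few. Any claim that something is new, unique, unknown or untested is made for them only; others in the source may bear on it.

Three esters built on one shared core have been examined: compound 1 `Nc1ncnc2c1ncn2CC(O)C(=O)OCCO`, compound 2 `CC(C)OC(=O)C(O)Cn1cnc2c(N)ncnc21` and compound 3 `COC(=O)C(O)Cn1cnc2c(N)ncnc21`. In a functional assay on Vero cells (Chlorocebus sabaeus) for cytotoxicity (a higher number here means that more compound is tolerated, a lower number that less compound is tolerated), compound 1 gives > 400 ug/mL, which is a limit of the assay rather than a number. Compound 2 gives > 400 ug/mL in this assay, again a limit. Compound 3 gives > 400 ug/mL in this assay, also a limit. Consequently the steps among them are unreadable: a step that the two limits leave unreadable from compound 1 to compound 2, a step that the two limits leave unreadable from compound 1 to compound 3 and a step that the two limits leave unreadable from compound 2 to compound 3, since (the limit of > 400 ug/mL in this assay, at which 3 of the 3 values shown sit).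

Compound 4 `Nc1ncnc2c1ncn2CC(O)C(=O)OC1CCCCC1` differs from compound 3 by cyclohexyl in place of methyl on an oxygen next to a carbonyl group. The step from compound 2 to compound 3 is the nearest comparison, an exchange of the alkyl group on the same oxygen, and it could not be read. For the measured compounds named here, with no measured step showing any movement beyond the scatter, no change beyond the scatter is expected in this assay, so the step of a number no higher from compound 3 to compound 4 (the limit leaves the size open) is estimated to be flat. Compound 4 is therefore expected to sit at the limit again, with an estimate of 400 ug/mL and a range from 200 ug/mL to 400 ug/mL.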

Compound 4, minimum cytotoxic concentration: 100 ug/mL
Compound 4: middle estimate off by 4.0-fold (0.60 log units), on the high side; the measured number lies below the stated range.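

For the compounds shown here, this ester oxygen is the first place where a change shows up in this assay: cyclohexyl in place of methyl gives an at least 4.0-fold lower number from compound 3 to compound 4 (0.60 log units; beyond the scatter). The same holds for cyclohexyl in place of isopropyl, with an at least 4.0-fold lower number from compound 2 to compound 4 (0.60 log units; beyond the scatter), and for cyclohexyl in place of 2-hydroxyethyl, with an at least 4.0-fold lower number from compound 1 to compound 4 (0.60 log units; beyond the scatter), so the lower number does not depend on which of the three esters serves as the reference. From the compounds shown here alone, the steps among compound 1, compound 2 and compound 3 still cannot be read, and the full size of the three new steps stays open, because those three esters sit at a limit: the limit of > 400 ug/mL in this assay, at which 3 of the 4 values shown sit.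

The compounds shown leave open whether the lower number needs the six-membered ring or would also come with a longer open chain such as hexyl, or a smaller ring such as cyclopentyl, on the same oxygen. They also leave open how a carboxylic acid or an amide in place of the ester would stand in this assay.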